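A few compounds are considered here, and "the series" means these few. Any claim that something is new, unique, unknown or untested is made for them only; others in the source may bear on it.

Compound 2 `CCN(CC)c1ccc(NC(=O)c2c(-c3c(Cl)cccc3Cl)noc2CCOC)cc1` stands at the strong end of the two measured compounds: in a functional assay on CHO-K cells with growth hormone secretagogue receptor type 1 (Homo sapiens) as the target, read by FLIPR (a lower number here means a stronger inhibitor, a higher number a weaker inhibitor), compound 2 gives 115 nM, the lowest of the two numbers. Among the measured compounds shown here, its only neighbour, compound 1 `CCN(CC)c1ccc(NC(=O)c2c(-c3c(Cl)cccc3Cl)noc2C(C)C)cc1`, in this assay gives 861 nM. For the measured compounds named here, the single measured step, a 7.5-fold lower number from compound 1 to compound 2 (0.87 log units; beyond the scatter), came from putting 2-methoxyethyl in place of isopropyl on an aromatic carbon of the shared core.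

Compound 3 `CCN(CC)c1ccc(NC(=O)c2c(-c3c(Cl)cccc3Cl)noc2CN2CCCC2=O)cc1` differs from compound 2 by 2-oxopyrrolidin-1-yl in place of methoxymethyl on a saturated chain carbon bound to an aromatic carbon. Going by the values given here, the change again touches the chain on that aromatic carbon, so the one measured step is the only guide, and it speaks only loosely: it shows that this chain can be altered without loss, but the group now entering is larger and ring-shaped, unlike anything yet tested. Among the compounds with values here, no measured pair addresses such a ring, so the direction is uncertain. The step is expected to be a 2.2-fold higher number from compound 2 to compound 3 (0.34 log units; beyond the scatter), small and possibly within the scatter. For compound 3 the estimate in this assay is 250 nM, with a likely range from 70 nM to 900 nM.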

Compound 3, half-maximal inhibitory concentration: 98 nM
Estimate against measurement, compound 3: 2.6-fold (0.41 log units) above; low and high end bracket the measured number.
By their numbers in this assay, from the lowest: compounds 3 and 2 (each within the scatter of the next); then compound 1.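

In this assay, 2-oxopyrrolidin-1-yl in place of methoxymethyl gives a 1.2-fold lower number from compound 2 to compound 3 (0.07 log units; within the scatter), so the larger group, which brings a five-membered non-aromatic ring, cannot be told apart from the open chain it replaces. Set against the isopropyl group, (2-oxopyrrolidin-1-yl)methyl gives an 8.8-fold lower number from compound 1 to compound 3 (0.94 log units; beyond the scatter), so a second and quite different group now stands beyond the scatter from isopropyl, just as 2-methoxyethyl did. This position therefore accepts both a ring-bearing group and an open chain with no measurable difference between them, although nothing available explains why either one differs from isopropyl.

The three compounds cannot show whether the ring's carbonyl matters, and a plain amine such as pyrrolidin-1-yl, attached through the same saturated chain carbon, would put that question directly, while a carboxylic acid on that carbon would test a very different kind of group. From the compounds shown here alone, the diethylamino group and the dichlorophenyl group are also identical in all three compounds, so whether the same changes at this position would give similar results alongside other groups there remains open.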